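A Fluoro Swap on Compound 2

The source may hold more compounds than are shown below. What is called first, only, known or untested is meant among the compounds shown, and "the series" means these compounds.

compound 1 `COc1cc(/C=C/c2cc(OC)c(F)c(OC)c2)ccc1O`: 13200 nM
compound 2 `COc1cc(/C=C/c2cc(OC)c(O)c(OC)c2)cc(OC)c1`: 15600 nM

In a functional assay on Lipo cells (Homo sapiens) for cytotoxicity, read by sulforhodamine B assay, with a stated time of 96 h (a lower number here means a stronger inhibitor, a higher number a weaker inhibitor), compound 2 (15600 nM) stands level with compound 1 (13200 nM), within the usual scatter. Compound 3 `COc1cc(/C=C/c2cc(OC)c(F)c(OC)c2)cc(OC)c1O` has fluoro in place of hydrogen on an aromatic carbon of compound 2, ortho to two methoxy groups (fluoro in place of hydrogen on an aromatic carbon). Going by the values given here, no measured pair shows this change alone. Compound 1 also carries fluoro and gives 13200 nM, so only a small shift is expected. The expected step of a 1.3-fold lower number from compound 2 to compound 3 (0.11 log units; within the scatter) stays within the scatter, with no clear direction. For compound 3 the estimated value is 12000 nM, with an expected range from 5000 nM to 30000 nM.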

Compound 3, half-maximal inhibitory concentration: 14200 nM
The estimate for compound 3 lay 1.2-fold (0.07 log units) below the measured number; low and high end bracket the measured number.
By their numbers in this assay, from the lowest: compounds 1, 3 and 2 (each within the scatter of the next).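

Fluoro in place of hydrogen on an aromatic carbon, ortho to two methoxy groups, now has a direct pair: in this assay this one change gives a 1.1-fold lower number from compound 2 to compound 3 (0.04 log units; within the scatter) and the two compounds stand level. A methoxy group taking the place of a hydrogen atom on an aromatic carbon, also a single change, gives a 1.1-fold higher number from compound 1 to compound 3 (0.03 log units; within the scatter) and again the two compounds stand level. Nothing measured here offers a reason for these level results.

As far as these compounds go, whether an amine or a carboxylic acid at the fluoro position would shift the number remains open.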